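The source may hold more compounds than are shown below. What is called first, only, known or untested is meant among the compounds shown, and "the series" means these compounds.

Among the compounds with values here, compound 2, `CCCCC(=O)N1CCN(c2nc(=O)c3cc(C(F)(F)F)cc([N+](=O)[O-])c3s2)CC1`, gives 42.5 ug/mL in a physicochemical assay for solubility, read by HPLC (on this read-out lower numbers stand for lower solubility and higher numbers for higher solubility), the highest of the three numbers measured so far. Compound 1, `O=c1nc(N2CCN(CC3CCCCC3)CC2)sc2c([N+](=O)[O-])cc(C(F)(F)F)cc12`, gives 9.07 ug/mL in this assay, and compound 3, `Cc1ccc(C(=O)N2CCN(c3nc(=O)c4cc(C(F)(F)F)cc([N+](=O)[O-])c4s3)CC2)cc1`, gives 6.7 ug/mL in the same assay. The steps are a 4.7-fold higher number from compound 1 to compound 2 (0.67 log units; beyond the scatter), a 6.3-fold lower number from compound 2 to compound 3 (0.80 log units; beyond the scatter) and a 1.4-fold lower number from compound 1 to compound 3 (0.13 log units; within the scatter).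

Compound 4, `O=C(C1CCC1)N1CCN(c2nc(=O)c3cc(C(F)(F)F)cc([N+](=O)[O-])c3s2)CC1`, is the next member. It differs from compound 2 in one place: cyclobutyl in place of butyl on a carbonyl carbon. Within the data shown here, the only measured step that touches the same carbonyl carbon is the one from compound 2 to compound 3, where 4-methylphenyl replaced butyl and gave a 6.3-fold lower number from compound 2 to compound 3 (0.80 log units; beyond the scatter). There a ring entered in place of the open chain and the number fell beyond the scatter. In compound 4 a ring also enters, but a small saturated one, and the count of heavy atoms is unchanged. Among the measured compounds shown here, no measured pair shows a chain closed into a saturated ring of the same size, so the expectation rests on the compound 2 to compound 3 step alone, read as an upper bound on the size of the drop. A fall smaller than that step, at or a little beyond the scatter, is expected: a 1.7-fold lower number from compound 2 to compound 4 (0.23 log units; within the scatter). Compound 4 is therefore estimated at 25 ug/mL, within 10 ug/mL to 55 ug/mL.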

Compound 4, solubility: 39.3 ug/mL
The estimate for compound 4 lay 1.6-fold (0.20 log units) below the measured number; low and high end bracket the measured number.
By their numbers in this assay, from the lowest: compounds 3 and 1 (each within the scatter of the next); then compounds 4 and 2 (each within the scatter of the next).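

In this assay cyclobutyl in place of butyl on a carbonyl carbon gives (a 1.1-fold lower number from compound 2 to compound 4 (0.03 log units; within the scatter)), so here a saturated ring of the same heavy-atom count cannot be told apart from the open chain. Cyclobutyl in place of 4-methylphenyl gives (a 5.9-fold higher number from compound 3 to compound 4 (0.77 log units; beyond the scatter)), which shows that a ring on this carbonyl carbon does not by itself go with the low number of compound 3, while cyclobutylcarbonyl in place of cyclohexylmethyl on an amine nitrogen in a ring gives (a 4.3-fold higher number from compound 1 to compound 4 (0.64 log units; beyond the scatter)), in line with compound 2 but against compound 3, the carbonyl compound that stays within the scatter of compound 1. No measurement offered here accounts for any of these steps.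

On these data alone, whether the number at this carbonyl carbon stays level with a longer chain or with a cyclohexyl ring remains open, as does whether the drop at compound 3 belongs to the aromatic ring or to its methyl group. A chain carrying an amine or a carboxylic acid at this carbonyl carbon is also untested among the compounds shown.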